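This account rests on a few compounds, and the source may have more. Where it says the series, first, only, none or still open, it means among the compounds named here.

Notes on the series. Compound 2 `COc1cccc(-c2c(C)n(Cc3c(F)cccc3F)c(=O)n(C[C@H](NC(C)C)C3CCCCC3)c2=O)c1F` holds the lowest of the two numbers measured in an assay on HEK293 cells for binding affinity to Gonadotropin-releasing hormone receptor (Homo sapiens), read by radioligand binding; on this read-out lower numbers stand for stronger inhibition and higher numbers for weaker inhibition; compound 2 gives 23 nM, and its nearest neighbour, compound 1 `COc1cccc(-c2c(C)n(Cc3c(F)cccc3F)c(=O)n(C[C@@H](N)CCc3ccccc3)c2=O)c1F`, gives 965 nM, the gap being a 42-fold lower number from compound 1 to compound 2 (1.62 log units; beyond the scatter). Compound 3 `COc1cccc(-c2c(C)n(Cc3c(F)cccc3F)c(=O)n(C[C@@H](N)C3CCCCC3)c2=O)c1F` is not yet measured. It differs from compound 2 in one place: amino(cyclohexyl)methyl in place of cyclohexyl(isopropylamino)methyl on a saturated chain carbon bound to an aromatic nitrogen. Within the data shown here, the single measured step bears on this only in part, since a 42-fold lower number from compound 1 to compound 2 (1.62 log units; beyond the scatter) came from replacing 1-amino-3-phenylpropyl by cyclohexyl(isopropylamino)methyl as a whole. Two numbers do not separate the change at the amine from the change at the ring; compound 3, bearing amino(cyclohexyl)methyl, shares the ring of compound 2 and the amine of compound 1. The expected step is a 4.3-fold higher number from compound 2 to compound 3 (0.64 log units; beyond the scatter), a rise beyond the scatter but smaller than the whole of the measured step. Compound 3 is estimated at 100 nM, within 30 nM to 400 nM.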

Compound 3, inhibition constant: 46 nM
Compound 3: the middle estimate sits 2.2-fold (0.34 log units) above what was measured, and the stated range covers the measured number.
By their numbers in this assay, from the lowest: compounds 2 and 3 (each within the scatter of the next); then compound 1.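

Notes on compound 3. In this assay, removing the isopropyl group from the amine gives a 2.0-fold higher number from compound 2 to compound 3 (0.30 log units; within the scatter), so this change does not register beyond the scatter in the cyclohexyl pair. The exchange at the saturated chain carbon gives a 21-fold lower number from compound 1 to compound 3 (1.32 log units; beyond the scatter), which places most of the large earlier step at the change from phenethyl to cyclohexyl, with the primary amine held constant. No measurement on hand gives a cause for either step.

The compounds shown leave open whether the phenethyl penalty follows the aromatic ring or the chain length, a question that a 2-cyclohexylethyl or a directly attached phenyl group on that carbon would address. Going by these compounds, it also remains open whether an isopropyl or ethyl group on the amine would behave the same way alongside phenethyl.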